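A few compounds are considered here, and "the series" means these few. Any claim that something is new, unique, unknown or untested is made for them only; others in the source may bear on it.

Notes on the series: in an ADME assay on L6 cells (Rattus norvegicus) for cytotoxicity, read by resazurin assay, with a stated time of 72 h (a lower number here means a stronger inhibitor, a higher number a weaker inhibitor), compound 2 `CN1CCN(CCC(=O)NC2CC3(N4CCCCC4)CC(c4ccccc4)C2C(c2ccccc2)C3)CC1` gives 61100 nM, the higher of the two numbers so far, and compound 1 `CN1CCN(CC(=O)OC2CC3(N4CCCC4)CC(c4ccccc4)C2C(c2ccccc2)C3)CC1` gives 24600 nM, a gap beyond the scatter. Compound 3 `CN1CCN(CCC(=O)NC2CC3(N4CCCC4)CC(c4ccccc4)C2C(c2ccccc2)C3)CC1` differs from compound 2 by pyrrolidin-1-yl in place of piperidin-1-yl on a saturated ring carbon, with pyrrolidin-1-yl in place of piperidin-1-yl on a saturated ring carbon. Within the data shown here, no matched step exists in this assay for this change. Compound 1 also carries pyrrolidin-1-yl but differs elsewhere too, so only a small move towards a lower number is expected, possibly none beyond the scatter. The expected change is a 1.3-fold lower number from compound 2 to compound 3 (0.10 log units; within the scatter). For compound 3 the estimated value is 48000 nM, with an expected range of 22000 nM to 100000 nM.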

Compound 3, half-maximal inhibitory concentration: 86700 nM
Estimate against measurement, compound 3: 1.8-fold (0.26 log units) below; low and high end bracket the measured number.
By their numbers in this assay, from the lowest: compound 1; then compounds 2 and 3 (each within the scatter of the next).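

In this assay, pyrrolidin-1-yl in place of piperidin-1-yl on this saturated ring carbon gives a 1.4-fold higher number from compound 2 to compound 3 (0.15 log units; within the scatter), so this swap does not separate the two compounds. With pyrrolidin-1-yl held constant, the ((2-(4-methylpiperazin-1-yl)ethyl)carbonyl)amino group in place of (((4-methylpiperazin-1-yl)methyl)carbonyl)oxy gives a 3.5-fold higher number from compound 1 to compound 3 (0.55 log units; beyond the scatter), so the clear gap lies with that side chain rather than the ring amine. No measurement available accounts for either step. From the compounds shown here alone, that single step alters both the linking atoms and the chain, so their separate contributions remain open. Also open, going by these compounds, is whether a dimethylamino group on the same ring carbon would move the number beyond the scatter.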